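Swapping a cyanophenyl for an amidoxime-bearing phenyl in a cytotoxicity series

The source may report more compounds than this note shows. Statements on the series, on what has been measured and on what is new or still open speak of the compounds shown alone.

Measured so far:
compound 1 `CC1(Cc2ccccc2)CC(S(=O)(=O)c2cccc(C(F)(F)F)c2)=C(c2ccc(/C(N)=N\O)cc2)O1`, 33400 nM
compound 2 `CC1(c2ccc(-c3ccccc3C#N)cc2)CC(S(=O)(=O)c2ccc(F)cc2)=C(c2ccc(/C(N)=N\O)cc2)O1`, 58300 nM
compound 3 `CC1(Cc2ccccc2)CC(S(=O)(=O)c2ccccc2F)=C(c2ccc(/C(N)=N\O)cc2)O1`, 61700 nM

The three compounds share one core and were tested in an ADME assay on HepG2 cells (Homo sapiens) for cytotoxicity, read by MTT assay, with a stated time of 72 h; on this read-out lower numbers stand for higher toxicity in this test and higher numbers for lower toxicity in this test. Compound 2 gives 58300 nM, a number that sits within the usual scatter of both compound 3 and compound 1, so none of the three can be told apart on toxicity.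

The unmeasured compound 4 `CC1(c2ccc(-c3cccc(/C(N)=N\O)c3)cc2)CC(S(=O)(=O)c2ccc(F)cc2)=C(c2ccc(/C(N)=N\O)cc2)O1` differs from compound 2 in one place: a group of 10 heavy atoms (7 carbon, 2 nitrogen, 1 oxygen; one six-membered aromatic ring of carbon only) in place of a group of 8 heavy atoms (7 carbon, 1 nitrogen; one six-membered aromatic ring of carbon only), on an aromatic carbon. Within the data shown here, the only step measured so far, a 1.8-fold higher number from compound 1 to compound 3 (0.27 log units; within the scatter), concerns the group on the sulfonyl sulfur, not the place changed here, and it stayed within the scatter. Among the measured compounds shown here, no measured step therefore speaks directly to this change, and every number seen so far lies in one narrow band. The expectation for compound 4 is a step of a 1.0-fold higher number from compound 2 to compound 4 (0.01 log units; within the scatter), that is, no change beyond the scatter. Compound 4 is thus estimated at 60000 nM in this assay, with a range from 25000 nM to 130000 nM.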

Compound 4, half-maximal cytotoxic concentration: 19000 nM
Compound 4: the middle estimate sits 3.2-fold (0.50 log units) above what was measured, and the stated range ends above it.
By their numbers in this assay, from the lowest: compounds 4, 1, 2 and 3 (each within the scatter of the next, the first and the last beyond it).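

In this assay, the change on this aromatic carbon, para to a large group, gives a 3.1-fold lower number from compound 2 to compound 4 (0.49 log units; beyond the scatter): the 2-cyanophenyl leaves and a larger amidoxime-bearing group enters. Among these compounds, this is the first step here to go beyond the scatter, and the lower number means higher toxicity in this test, whereas the change on the sulfonyl sulfur, a 1.8-fold higher number from compound 1 to compound 3 (0.27 log units; within the scatter), stayed within it. So this one position can shift the read-out, though the shift is modest and rests on a single pair, and no available measurement explains it.

Removing the nitrile and adding the amidoxime happen in the same step, so the compounds shown leave open which of the two matters. A plain phenyl group or an aminophenyl group at this place could help separate them.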